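The compounds below may be only part of what the source reports. "The series", "measured", "known", "first", "only" and "open" are said of these compounds alone.

In a physicochemical assay for solubility (on this read-out lower numbers stand for lower solubility and higher numbers for higher solubility), compound 2 `CNC(=O)c1cc(C(=O)NCCO)n([C@@H](C)c2ccccc2)n1` gives >= 139 ug/mL, which is a limit and not a number. Compound 3 `CNC(=O)c1cc(C(=O)N[C@H]2CC[C@H](OC)CC2)n([C@@H](C)c2ccccc2)n1` differs from it in one place, on an amide-type nitrogen: 4-methoxycyclohexyl stands in place of 2-hydroxyethyl, as counted here: 4-methoxycyclohexyl in place of 2-hydroxyethyl on an amide-type nitrogen. Among the measured compounds shown here, only one measured step bears on this change, and it sits on the same kind of nitrogen: a step that the two limits leave unreadable from compound 1 to compound 2. Its size cannot be read, so it gives no direction. Compound 1 `CNC(=O)c1cc(C(=O)N[C@H]2[C@@H]3C[C@@H](OC)C[C@@H]32)n([C@@H](C)c2ccccc2)n1`, which carries a ring-bearing group on that nitrogen, gives >= 150 ug/mL, and this too is a limit. The expected step, a step that the limit leaves unreadable from compound 2 to compound 3, is therefore no larger than the usual scatter, with neither direction favoured. The estimate for compound 3 is 150 ug/mL, with an expected range from 70 ug/mL to 300 ug/mL.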

Compound 3, solubility: >= 161 ug/mL
Compound 3 was reported as a limit; the forecaster's own chance of this, stated with the estimate: 60%; at least 1.0-fold (0.03 log units) between middle value and limit.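

In this assay compound 3 gives >= 161 ug/mL, which is a limit. Among the compounds shown here, compound 1, compound 2 and compound 3 all stand as limits, so no step among them can be read. The compounds shown leave open whether 4-methoxycyclohexyl or 2-hydroxyethyl on the amide-type nitrogen gives the higher solubility.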